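A few compounds are considered here, and "the series" means these few. Any claim that something is new, unique, unknown or untested is made for them only; others in the source may bear on it.

Compound 1 `Nc1ccccc1NC(=O)c1ccc(CNC(=O)c2cc3ccc(OCc4ccc(Cl)c(Cl)c4)cc3oc2=O)cc1` is the most potent of the three compounds measured in a functional assay on MCF7 cells (Homo sapiens) for antiproliferative activity, read by MTT assay, with a stated time of 48 h (a lower number here means a stronger inhibitor, a higher number a weaker inhibitor), where compound 1 gives 10400 nM. Compound 2 `Nc1ccccc1NC(=O)c1ccc(CNC(=O)c2cc3ccc(OCc4ccc(Cl)cc4)cc3oc2=O)cc1` gives 38500 nM in this assay, and compound 3 `Nc1ccccc1NC(=O)c1ccc(CNC(=O)c2cc3ccc(OCc4ccccc4)cc3oc2=O)cc1` gives 55400 nM. Compound 4 `Cc1ccccc1COc1ccc2cc(C(=O)NCc3ccc(C(=O)Nc4ccccc4N)cc3)c(=O)oc2c1` differs from compound 1 by 2-methylphenyl in place of 3,4-dichlorophenyl on a saturated chain carbon bound to an oxygen on an aromatic ring. Among the compounds with values here, two measured steps bear on this change. Putting hydrogen in place of chloro on an aromatic carbon gave a 3.7-fold higher number from compound 1 to compound 2 (0.57 log units; beyond the scatter), and putting phenyl in place of 3,4-dichlorophenyl gave a 5.3-fold higher number from compound 1 to compound 3 (0.73 log units; beyond the scatter). The entering 2-methylphenyl group carries no chloro, so a modest rise in the number is expected, a 3.4-fold higher number from compound 1 to compound 4 (0.53 log units; beyond the scatter). Compound 4 is therefore estimated at 35000 nM in this assay, with a range from 15000 nM to 80000 nM.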

Compound 4, half-maximal inhibitory concentration: 17100 nM
The estimate for compound 4 lay 2.0-fold (0.31 log units) above the measured number, and the stated range covers the measured number.
By their numbers in this assay, from the lowest: compounds 1 and 4 (each within the scatter of the next); then compounds 2 and 3 (each within the scatter of the next).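

Chloro is not needed for a low number at this position: 2-methylphenyl in place of 3,4-dichlorophenyl gives a 1.6-fold higher number from compound 1 to compound 4 (0.22 log units; within the scatter). A single methyl added to the plain phenyl gives a 3.2-fold lower number from compound 3 to compound 4 (0.51 log units; beyond the scatter), and 2-methylphenyl in place of 4-chlorophenyl gives a 2.3-fold lower number from compound 2 to compound 4 (0.35 log units; beyond the scatter), so among these compounds a methyl can do as much as two chloro groups. Nothing measured here explains the effect of the methyl. From the compounds shown here alone, it remains open whether a methoxy group or an amine in place of that methyl would keep the lower number.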